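A few compounds are considered here, and "the series" means these few. Any claim that something is new, unique, unknown or untested is made for them only; others in the source may bear on it.

Measured compounds:
Compound 1 `O=C1c2c[n+]([O-])c3ccccc3c2C(=O)c2c1c1ccccc1n2Cc1cn(C[C@@H](O)CO)nn1` — 2030 nM
Compound 2 `CC1(C)O[C@@H](CO)[C@H](Cn2cc(Cn3c4c(c5ccccc53)C(=O)c3c[n+]([O-])c5ccccc5c3C4=O)nn2)O1` — 120 nM
Compound 3 `CC1(C)OCC(Cn2cc(Cn3c4c(c5ccccc53)C(=O)c3c[n+]([O-])c5ccccc5c3C4=O)nn2)O1` — 5510 nM

In a toxicity assay on HEK-293T cells (Homo sapiens) for cytotoxicity, read by MTT assay, with a stated time of 72 h (on this read-out lower numbers stand for stronger inhibition and higher numbers for weaker inhibition), compound 3 gives the highest number of the three. Its nearest neighbour is compound 1, a 2.7-fold higher number from compound 1 to compound 3 (0.43 log units; beyond the scatter), and its furthest is compound 2, a 46-fold higher number from compound 2 to compound 3 (1.66 log units; beyond the scatter).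

Compound 4 `O=C1c2c[n+]([O-])c3ccccc3c2C(=O)c2c1c1ccccc1n2Cc1cn([C@@H]2C[C@H](O)[C@@H](CO)O2)nn1` differs from compound 3 in one place: 4-hydroxy-5-(hydroxymethyl)oxolan-2-yl in place of (2,2-dimethyl-1,3-dioxolan-4-yl)methyl on an aromatic nitrogen. Among the compounds with values here, no earlier step changes the same position in this way, so the steps among the hydroxyl-bearing side groups are the closest guide. The step of a 17-fold lower number from compound 1 to compound 2 (1.23 log units; beyond the scatter) shows that a group carrying a hydroxymethyl on its ring sits far lower than the open diol, and the step of a 46-fold higher number from compound 2 to compound 3 (1.66 log units; beyond the scatter) shows that losing that hydroxymethyl raises the number sharply. Compound 4 brings two hydrogen-bond donors, including a hydroxymethyl on its ring, while compound 3 carries none. Within the data shown here, the expectation is therefore a lower number than compound 3 in this assay, likely landing between compound 1 and compound 2, though the shift from a chain-linked to a directly ring-linked group has no measured counterpart and widens the uncertainty.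

Compound 4 is estimated at 700 nM, with a range from 150 nM to 3500 nM, meaning an expected step of a 7.9-fold lower number from compound 3 to compound 4 (0.90 log units; beyond the scatter).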

Compound 4, half-maximal inhibitory concentration: 820 nM
Estimate against measurement, compound 4: 1.2-fold (0.07 log units) below; the range from low to high includes it.
By their numbers in this assay, from the lowest: compound 2; then compound 4; then compound 1; then compound 3.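

In this assay, 4-hydroxy-5-(hydroxymethyl)oxolan-2-yl on this aromatic nitrogen gives a 6.7-fold lower number from compound 3 to compound 4 (0.83 log units; beyond the scatter) and so recovers part of what was lost with the hydroxymethyl-free (2,2-dimethyl-1,3-dioxolan-4-yl)methyl group. The same change still leaves a 6.8-fold higher number from compound 2 to compound 4 (0.83 log units; beyond the scatter) when it replaces (5-(hydroxymethyl)-2,2-dimethyl-1,3-dioxolan-4-yl)methyl, which shows that a ring carrying a hydroxymethyl does not by itself reach the low number of compound 2. Against the open 2,3-dihydroxypropyl group it gives a 2.5-fold lower number from compound 1 to compound 4 (0.39 log units; beyond the scatter) as a modest gain, so among these four compounds both hydroxymethyl-bearing rings stand lower than the open diol, and the ring without one stands higher.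

Each of these swaps alters the ring and its attachment to the nitrogen together, so the compounds shown cannot separate the two, and they leave open whether an amine in place of the ring hydroxyl, or a longer chain carrying the same oxolane ring, would move the number further. Nothing given here accounts for why these groups differ in this assay.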